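This account rests on a few compounds, and the source may have more. Where it says the series, first, only, none or still open, it means among the compounds named here.

Measured so far:
Compound 1 `CC(C)(C)n1ncc(OCc2nnc(-c3ccc(Br)cc3)o2)c(Cl)c1=O`: 21400 nM
Compound 2 `CC(C)(C)n1ncc(OCc2nnc(-c3cccc(F)c3)o2)c(Cl)c1=O`: 7100 nM
Compound 3 `CC(C)(C)n1ncc(OCc2nnc(-c3ccccc3)o2)c(Cl)c1=O`: 12200 nM

In a functional assay on the whole organism for inhibition, with Mythimna separata as the target, with a stated time of 5 days (on this read-out lower numbers stand for an effect already at smaller amounts and higher numbers for an effect only at larger amounts of compound), compound 3 holds the second highest of the three numbers, and its gaps to both neighbours are small: a 1.7-fold higher number from compound 2 to compound 3 (0.24 log units; within the scatter) and a 1.8-fold lower number from compound 1 to compound 3 (0.24 log units; within the scatter). Compound 4 `CC(C)(C)n1ncc(OCc2nnc(-c3ccc(Cl)cc3Cl)o2)c(Cl)c1=O` carries 2,4-dichlorophenyl in place of phenyl on an aromatic carbon. For the measured compounds named here, the steps that bear on this change all concern halogens on the same phenyl: a 1.8-fold lower number from compound 1 to compound 3 (0.24 log units; within the scatter) stayed within the scatter, while a 3.0-fold lower number from compound 1 to compound 2 (0.48 log units; beyond the scatter) was modest. Only the shift from a 4-bromophenyl to a 3-fluorophenyl moved the number clearly; adding or removing a single halogen did not. Two chlorines on the ring are therefore expected to change little, and compound 4 is estimated at 14000 nM (range 5000 nM to 40000 nM), a step of a 1.1-fold higher number from compound 3 to compound 4 (0.06 log units; within the scatter) expected to fall within the scatter.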

Compound 4, half-maximal effective concentration: 27800 nM
For compound 4 the middle estimate is 2.0-fold (0.30 log units) below the measured one; the measured number falls inside the stated range.
By their numbers in this assay, from the lowest: compounds 2, 3, 1 and 4 (each within the scatter of the next, the first and the last beyond it).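

In this assay, 2,4-dichlorophenyl gives the first step away from the plain phenyl that lies beyond the scatter: a 2.3-fold higher number from compound 3 to compound 4 (0.36 log units; beyond the scatter). Halogens on this phenyl can therefore matter, and a 3.9-fold higher number from compound 2 to compound 4 (0.59 log units; beyond the scatter) is the largest of the new steps, while a 1.3-fold higher number from compound 1 to compound 4 (0.11 log units; within the scatter) stays within the scatter. Nothing available explains these steps.

The compounds shown leave open whether either chlorine alone would produce this step. They also leave open how a methoxy group or an amine on this phenyl would read.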